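This account rests on a few compounds, and the source may have more. Where it says the series, first, only, none or still open, it means among the compounds named here.

Measured so far in a functional assay on HCT-116 cells (Homo sapiens) for antiproliferative activity, read by MTT assay, with a stated time of 48 h; on this read-out higher numbers stand for weaker inhibition and lower numbers for stronger inhibition:
compound 1 `O=C(/C=C/c1cccc(NS(=O)(=O)c2cccc(Cl)c2)c1)c1nc2ccccc2[nH]1`, 737 nM
compound 2 `O=C(/C=C/c1cccc(NS(=O)(=O)c2cc(Cl)cc(Cl)c2)c1)c1nc2ccccc2[nH]1`, 2840 nM

Among the compounds with values here, compound 2 gives the higher of the two numbers in this assay; its nearest neighbour is compound 1, and the one step known, a 3.9-fold higher number from compound 1 to compound 2 (0.59 log units; beyond the scatter), separates them. Compound 3 `Cc1cc(C)cc(S(=O)(=O)Nc2cccc(/C=C/C(=O)c3nc4ccccc4[nH]3)c2)c1` is not yet measured. Its change from compound 2 is 3,5-dimethylphenyl in place of 3,5-dichlorophenyl on a sulfonyl sulfur. Within the data shown here, no measured step swaps chloro for methyl on this ring, so the single known step bears only loosely: a 3.9-fold higher number from compound 1 to compound 2 (0.59 log units; beyond the scatter) shows that the substitution on this ring moves the number in this assay by a modest amount. Whether the dimethyl pattern brings the number back toward compound 1 cannot be read from two values. The step from compound 2 to compound 3 is therefore expected to be small, a 1.6-fold lower number from compound 2 to compound 3 (0.20 log units; within the scatter), with wide uncertainty either way. Compound 3 is estimated at 1800 nM, range 500 nM to 6000 nM.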

Compound 3, half-maximal inhibitory concentration: 1220 nM
Compound 3: middle estimate off by 1.5-fold (0.17 log units), on the high side; measured number inside the range.
By their numbers in this assay, from the lowest: compounds 1 and 3 (each within the scatter of the next); then compound 2.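

In this assay, 3,5-dimethylphenyl in place of 3,5-dichlorophenyl on the sulfonyl sulfur gives a 2.3-fold lower number from compound 2 to compound 3 (0.37 log units; beyond the scatter), so among these compounds the number depends on which groups the ring carries and not only on how many. Within the data shown here, compound 2 alone could not show this, since its only measured neighbour differed by one added chloro. The comparison with the 3-chlorophenyl compound, a 1.7-fold higher number from compound 1 to compound 3 (0.22 log units; within the scatter), shows that a ring with two substituents can stay within the scatter of compound 1, and no measurement on hand accounts for the difference between the chloro and methyl pairs.

Still open, from the compounds shown here alone, is how the unsubstituted phenyl, or a phenyl carrying a methoxy group, an amine or a carboxylic acid, would read in this assay. Also open, going by these compounds, is whether a longer alkyl chain can replace the aromatic ring on the sulfonyl sulfur.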